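The compounds below may be only part of what the source reports. "The series", "measured", "known", "first", "only" and "open" are said of these compounds alone.

Of the compounds shown here, two of one series have been tested in a functional assay on the whole organism (strain Wistar) for inhibition, with Rattus norvegicus as the target, with stated times of 30 min and 3 h, at a dose of 20 mg/kg by the oral route; on this read-out higher numbers stand for more inhibition at the one dose given (going by the name of the read-out) and lower numbers for less inhibition. Compound 1, `Cc1ccc(C(=O)CCc2nnc(-c3ccccc3)o2)c(C)c1`, gives 58% in this assay. Compound 2, `Cc1ccc(C(=O)CCc2nnc(Cc3ccccc3)o2)cc1`, gives 51.9% in this assay, and its number is the smaller of the two known, though the gap to compound 1 stays within the usual scatter, so the two cannot be told apart on these data.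

Compound 3, `Cc1ccc(C(=O)CCc2nnc(Cc3ccccc3)o2)c(C)c1`, has not been measured. It differs from compound 2 in one place: methyl in place of hydrogen on an aromatic carbon. Read one bond further out, the change is 4-methylphenyl to 2,4-dimethylphenyl, the same group that compound 1 carries on that side of the shared core.

For the measured compounds named here, no step between measured compounds bears on this change, so the expected step from compound 2 to compound 3, a number 3.1 percentage points higher from compound 2 to compound 3 (within the scatter), is small and not beyond the scatter. Compound 3 is therefore estimated to give 55% in this assay, within a range of 35% to 75%.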

Compound 3, a percentage reported as inhibition, in the whole organism at one dose (the size of the read-out at that dose, not a potency): 50%
Beside the measured number, compound 3's estimate is 5 percentage points above it; low and high end bracket the measured number.
By their numbers in this assay, from the lowest: compounds 3, 2 and 1 (each within the scatter of the next).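

In this assay, methyl on the aromatic carbon ortho to a large group, which turns 4-methylphenyl into 2,4-dimethylphenyl, gives a number 1.9 percentage points lower from compound 2 to compound 3 (within the scatter) and so leaves the read-out at this dose indistinguishable with benzyl on the other side of the shared core. Benzyl in place of phenyl, with 2,4-dimethylphenyl held fixed, gives a number 8 percentage points lower from compound 1 to compound 3 (within the scatter) and cannot be told from the scatter either. Neither single change therefore separates its two compounds on these data. Nothing at hand offers an explanation for these steps.

On these data alone, whether a methoxy group or a chlorine atom at that same ring position would give a step beyond the scatter remains open. So does the effect of an amine or a carboxylic acid on the benzyl ring.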